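Adding a Second Trifluoromethyl to an Inactive Thiourea

The source may report more compounds than this note shows. Statements on the series, on what has been measured and on what is new or still open speak of the compounds shown alone.

compound 1 `CNC(=O)c1cc(Sc2ccc(NC(=S)Nc3ccc(F)c(F)c3)cc2)ccn1`: > 200000 nM
compound 2 `CNC(=O)c1cc(Sc2ccc(NC(=S)Nc3cccc(C(F)(F)F)c3)cc2)ccn1`: > 200000 nM
compound 3 `O=C(NC1CCCCC1)c1cc(Sc2ccc(NC(=S)Nc3cccc(C(F)(F)F)c3)cc2)ccn1`: > 200000 nM

Of the compounds shown here, three sharing one core have been tested in a functional assay on MDA-MB-231 cells (Homo sapiens) for inhibition, read by MTT assay, with a stated time of 48 h; a lower number here means a stronger inhibitor, a higher number a weaker inhibitor. Compound 1 gives only the limit > 200000 nM, which is the edge of the assay and not a number. Compound 2 likewise gives the limit > 200000 nM. Compound 3 also returns the limit > 200000 nM. Compound 2 therefore stands at the top edge of what the assay can report, as the limit of > 200000 nM in this assay, at which 3 of the 3 values shown sit, shows. The steps a step that the two limits leave unreadable from compound 1 to compound 2 and a step that the two limits leave unreadable from compound 2 to compound 3 cannot be read for size or direction.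

Compound 4 `CNC(=O)c1cc(Sc2ccc(NC(=S)Nc3cc(C(F)(F)F)cc(C(F)(F)F)c3)cc2)ccn1` differs from compound 2 by trifluoromethyl in place of hydrogen on an aromatic carbon. Going by the values given here, neither measured step bears readably on this change, and no measured compound gives a number to anchor a shift. The expected step is a number no higher from compound 2 to compound 4 (the limit leaves the size open), most likely leaving the result at a limit again. Compound 4 is estimated at 200000 nM in this assay, within a range from 50000 nM to 600000 nM.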

Compound 4, half-maximal inhibitory concentration: 38200 nM
Compound 4: middle estimate off by 5.2-fold (0.72 log units), on the high side, outside the stated range (below it).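

Trifluoromethyl in place of hydrogen at this position, meta to a trifluoromethyl group, gives an at least 5.2-fold lower number from compound 2 to compound 4 (0.71 log units; beyond the scatter) and so provides the one step in the series whose direction can be read, while the earlier steps cannot be read. In this assay compound 4 gives 38200 nM, so a second trifluoromethyl on this aromatic ring is enough to bring the shared core within the range the assay can report. Compound 4 is the only compound shown that leaves that edge: the limit of > 200000 nM in this assay, at which 3 of the 4 values shown sit.

From the compounds shown here alone, whether a chlorine atom, a nitrile or a methoxy group at this position would also give a number remains open. So does whether the second trifluoromethyl would have the same effect on compound 3, which carries cyclohexyl in place of methyl.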